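The source may report more compounds than this note shows. Statements on the series, on what has been measured and on what is new or still open speak of the compounds shown alone.

Working notes on the series of bis-benzothiazolyl amines.

Compound 2 `Clc1ccc2nc(Nc3nc4ccccc4s3)sc2c1` in a functional assay on THP-1 cells (Homo sapiens) for cytotoxicity, read by MTT assay, with a stated time of 48 h (on this read-out higher numbers stand for weaker inhibition and lower numbers for stronger inhibition), gives 45400 nM. The two neighbours on the shared core sit with it: compound 1 `Cc1ccc2nc(Nc3nc4ccccc4s3)sc2c1` gives 34200 nM and compound 3 `c1ccc2sc(Nc3nc4ccccc4s3)nc2c1` gives 28800 nM, and neither is separated from compound 2 beyond the scatter. Going by the values given here, the steps that join them are a 1.3-fold higher number from compound 1 to compound 2 (0.12 log units; within the scatter) and a 1.6-fold lower number from compound 2 to compound 3 (0.20 log units; within the scatter), with a 1.2-fold lower number from compound 1 to compound 3 (0.07 log units; within the scatter) between the two outer members; every one of them is within the scatter, so swapping methyl, chloro and hydrogen on that aromatic carbon has not moved the number so far.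

Compound 4 `Fc1ccc2nc(Nc3nc4ccc(Cl)cc4s3)sc2c1` differs from compound 2 by fluoro in place of hydrogen on an aromatic carbon. The change is again a small substituent exchange on an aromatic carbon of the same kind of ring, and the measured exchanges of that kind all stayed within the scatter, so no step beyond the scatter is expected in this assay in either direction. Compound 4 is therefore estimated at 40000 nM, with a range from 18000 nM to 90000 nM, which means an expected step of a 1.1-fold lower number from compound 2 to compound 4 (0.05 log units; within the scatter).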

Compound 4, half-maximal inhibitory concentration: 41000 nM
For compound 4 the middle estimate is 1.0-fold (0.01 log units) below the measured one; measured number inside the range.
By their numbers in this assay, from the lowest: compounds 3, 1, 4 and 2 (each within the scatter of the next).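

The earlier steps shown here only exchanged one group on one aromatic carbon, whereas here the chloro of compound 2 stays and fluoro enters at a second aromatic carbon, so compound 4 carries both halogens on the shared core. In this assay this addition gives a 1.1-fold lower number from compound 2 to compound 4 (0.04 log units; within the scatter), so the insensitivity seen at the first carbon also holds for this fluoro at the second, and all four compounds still lie within the scatter of their neighbours in the order of numbers. Nothing available explains this flat response.

Still open, going by these compounds, is whether an amine, a carboxylic acid or a longer chain on either aromatic carbon would give a step beyond the scatter. Also open, on these data alone, is how fluoro would read on this carbon with hydrogen in place of the chloro.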